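Amide to Urea on a Shared Pyrazole-Free Core Description

The compounds below may be only part of what the source reports. "The series", "measured", "known", "first", "only" and "open" are said of these compounds alone.

Compound 1 `COc1cc(-c2nn(-c3cccc(NC(=O)c4cccc(C(F)(F)F)c4)c3)cc2-c2ccncc2)ccc1Cl` gives 1320 nM in a functional assay on MDA-MB-468 cells (Homo sapiens) for inhibition, read by sulforhodamine B assay, with a stated time of 48 h; on this read-out higher numbers stand for weaker inhibition of growth and lower numbers for stronger inhibition of growth. Compound 2 `COc1cc(-c2nn(-c3cccc(NC(=O)Nc4ccc(Cl)c(Cl)c4)c3)cc2-c2ccncc2)ccc1Cl` gives 567 nM in this assay. Compound 3 `COc1cc(-c2nn(-c3cccc(NC(=O)c4ccc(Cl)c(C(F)(F)F)c4)c3)cc2-c2ccncc2)ccc1Cl` gives 3690 nM in this assay.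

Compound 3 stands at the highest number of the three, so it shows the weakest inhibition of growth; compound 1 is its nearest neighbour and compound 2 its furthest. Compound 4 `COc1cc(-c2nn(-c3cccc(NC(=O)Nc4ccc(Cl)c(C(F)(F)F)c4)c3)cc2-c2ccncc2)ccc1Cl` differs from compound 3 in one place: (4-chloro-3-(trifluoromethyl)phenyl)amino in place of 4-chloro-3-(trifluoromethyl)phenyl on a carbonyl carbon.

Among the measured compounds shown here, two measured steps bear on this change. The step of a 2.3-fold lower number from compound 1 to compound 2 (0.37 log units; beyond the scatter) also swaps an aryl group on the carbonyl carbon for an arylamino group, though the ring substituents change at the same time, and it lowered the number. The step of a 6.5-fold higher number from compound 2 to compound 3 (0.81 log units; beyond the scatter) runs the other way, from arylamino to aryl, and raised the number. Both point in the same direction: placing an amino between the carbonyl carbon and the aromatic ring goes with a lower number. A modest step downward beyond the scatter is therefore expected for compound 4, a 2.8-fold lower number from compound 3 to compound 4 (0.45 log units; beyond the scatter), because the step of a 2.3-fold lower number from compound 1 to compound 2 (0.37 log units; beyond the scatter) was of that size. Compound 4 is estimated at 1300 nM, within a range of 400 nM to 3500 nM.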

Compound 4, concentration for 50% growth inhibition: 833 nM
The estimate for compound 4 lay 1.6-fold (0.19 log units) above the measured number; measured number inside the range.
By their numbers in this assay, from the lowest: compounds 2, 4 and 1 (each within the scatter of the next, the first and the last beyond it); then compound 3.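

Among the compounds shown here, compound 3 and compound 4 carry the same 4-chloro-3-(trifluoromethyl)phenyl ring, so this pair isolates the amino on the carbonyl carbon, which the earlier steps could not do because the ring changed along with it; in this assay the pair shows a 4.4-fold lower number from compound 3 to compound 4 (0.65 log units; beyond the scatter) and so ties that amino alone to a lower number. With the amino in place, the ring change reads as a 1.5-fold higher number from compound 2 to compound 4 (0.17 log units; within the scatter) and the comparison with the amide carrying no chloro reads as a 1.6-fold lower number from compound 1 to compound 4 (0.20 log units; within the scatter), whereas on the amide the added chloro gave a 2.8-fold higher number from compound 1 to compound 3 (0.45 log units; beyond the scatter), so the penalty seen for compound 3 does not appear for compound 4. Nothing shown here gives a measured reason for these steps.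

The compounds shown leave open whether the amino brings a step of similar size to the 3-(trifluoromethyl)phenyl ring of compound 1, whose arylamino partner does not appear here. Also open, as far as these compounds go, is how an oxygen or a methylene would read on the carbonyl carbon in place of that amino, and how a ring bearing a carboxylic acid or an amine would read.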